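A few compounds are considered here, and "the series" means these few. Any claim that something is new, unique, unknown or untested is made for them only; others in the source may bear on it.

Measured compounds

Compound 1 `CN1CCN(c2ccc(Nc3ncc4nc(Nc5ccccc5)n([C@H]5CCN(S(C)(=O)=O)C5)c4n3)cc2)CC1` — 17 nM
Compound 2 `CN1CCN(c2ccc(Nc3ncc4nc(Nc5ccccc5)n([C@H]5CCN(S(=O)(=O)C6CC6)C5)c4n3)cc2)CC1` — 1.6 nM

Within the data shown here, in a functional assay on HCC827 cells (Homo sapiens) for antiproliferative activity, read by MTT assay, with a stated time of 72 h (a lower number here means a stronger inhibitor, a higher number a weaker inhibitor), compound 2 gives the lower of the two numbers, with the only single change measured being an 11-fold lower number from compound 1 to compound 2 (1.03 log units; beyond the scatter).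

Compound 3 `CN1CCN(c2ccc(Nc3ncc4nc(Nc5ccccc5)n([C@@H]5CCN(C(=O)OC(C)(C)C)C5)c4n3)cc2)CC1` is not yet measured. It differs from compound 2 in one place: 1-(tert-butoxycarbonyl)pyrrolidin-3-yl in place of 1-(cyclopropylsulfonyl)pyrrolidin-3-yl on an aromatic nitrogen.

Among the measured compounds shown here, the only measured step, from compound 1 to compound 2, concerns the group on the sulfonyl sulfur and was large. It bears on the present change only indirectly, since compound 3 retains no sulfonyl at all and carries a carbamate instead. For the measured compounds named here, no pair shows what exchanging the whole substituent on the pyrrolidine nitrogen does. Going by the values given here, the measured step suggests that this position is sensitive, so a change of some size in this assay is expected, and the loss of the group that gave the best number so far is taken to point toward a higher number. The estimate for compound 3 is therefore 8 nM, with a range of 2 nM to 40 nM, corresponding to an expected step of a 5.0-fold higher number from compound 2 to compound 3 (0.70 log units; beyond the scatter).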

Compound 3, half-maximal inhibitory concentration: 12 nM
For compound 3 the middle estimate is 1.5-fold (0.18 log units) below the measured one; the range from low to high includes it.
By their numbers in this assay, from the lowest: compound 2; then compounds 3 and 1 (each within the scatter of the next).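

In this assay, exchanging the whole substituent on the pyrrolidine nitrogen gives a 7.5-fold higher number from compound 2 to compound 3 (0.88 log units; beyond the scatter) and so costs activity when the group that leaves is 1-(cyclopropylsulfonyl)pyrrolidin-3-yl. The corresponding exchange from 1-(methylsulfonyl)pyrrolidin-3-yl gives a 1.4-fold lower number from compound 1 to compound 3 (0.15 log units; within the scatter) and so separates the two groups by no more than the scatter, which means that among these compounds, the presence of a sulfonyl does not by itself set a compound apart: the tert-butoxycarbonyl and methylsulfonyl members cannot be told apart, and only the cyclopropylsulfonyl member stands out. No supporting measurement bears on the reason for this difference.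

The compounds shown leave open whether the gain is specific to the cyclopropyl ring or would also appear with another group on the sulfonyl sulfur, such as ethyl, isopropyl or cyclobutyl. They also leave open how a free pyrrolidine amine, a simple acetyl amide or a cyclopropyl carbonyl amide on the same nitrogen would compare, the last of which would show whether the cyclopropyl gain carries over without the sulfonyl.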